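Swapping Cyclohexyl for Hydroxyethyl on an Adenosine Receptor Amide

The source may hold more compounds than are shown below. What is called first, only, known or untested is meant among the compounds shown, and "the series" means these compounds.

Among the measured compounds shown here, compound 1, `N=c1oc2ccc(Br)cc2cc1C(=O)NC1CCCCC1`, is one of two compounds measured in an assay on CHO cells for displacement of a labelled ligand from adenosine receptor A1 (Homo sapiens), read by scintillation counting, with a stated time of 60 min, tested at 10 uM; on this read-out lower numbers stand for less inhibition and higher numbers for more inhibition at the one concentration tested (going by the name of the read-out). In this assay compound 1 gives 5%, the only plain number shown. Compound 2, `COc1cccc2cc(C(=O)NC3CCCC3)c(=N)oc12`, gives > 70%, which is a limit of the assay and not a number, as the limit of > 70% in this assay, at which 1 of the 2 values shown sits, records. Compound 3, `N=c1oc2ccc(Br)cc2cc1C(=O)NCCO`, differs from compound 1 in one place: 2-hydroxyethyl in place of cyclohexyl on an amide-type nitrogen. For the measured compounds named here, no step between measured compounds is available, so the effect of this change is unknown, and a step no larger than the usual scatter, in either direction, is expected. Compound 3 is estimated at 6%, between -5% and 25%. The expected step of a number 1 percentage points higher from compound 1 to compound 3 (within the scatter) stays within the scatter.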

Compound 3, a percentage reported as inhibition, at one concentration (the size of the read-out at that concentration, not a potency): 26%
Compound 3: the middle estimate sits 20 percentage points below what was measured; measured number outside the range, above it.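

Among the compounds shown here, replacing cyclohexyl with 2-hydroxyethyl on the amide-type nitrogen gives a number 21 percentage points higher from compound 1 to compound 3 (beyond the scatter) in this assay, the first sign that the group at this place on the shared core affects the read-out. The ring is therefore not needed for this level of inhibition, although one pair cannot separate losing the ring from gaining the hydroxyl group. Nothing shown explains the direction of this step.

As far as these compounds go, it remains open whether a longer chain would change the read-out further. The same applies to an amine or a carboxylic acid at the end of the chain.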